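Replacing a nitrile with a hydrazide on a shared core

The compounds below may be only part of what the source reports. "The series", "measured", "known", "first", "only" and "open" are said of these compounds alone.

Compound 1 `N#Cc1cn(COCCO)c2ncnc(N)c12` carries a cyano group on the shared core. In an ADME assay on BSC-1 cells (Cercopithecidae) for cytotoxicity (on this read-out lower numbers stand for stronger inhibition and higher numbers for weaker inhibition), compound 1 gives > 320000 nM, which is a limit of the assay and not a number. Compound 1 thus stands at the limit of > 320000 nM in this assay, at which 1 of the 2 values shown sits. Its neighbour, compound 2 `NC(=S)c1cn(COCCO)c2ncnc(N)c12`, carries a thiocarbamoyl group in place of the cyano group. In this assay compound 2 gives > 100000 nM, again a limit of the assay rather than a number, so compound 2 stands at the limit of > 100000 nM in this assay, at which 1 of the 2 values shown sits. The step that the two limits leave unreadable from compound 1 to compound 2 cannot be read, since both ends are limits.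

The compound not yet measured, compound 3 `NNC(=O)c1cn(COCCO)c2ncnc(N)c12`, differs from compound 1 by aminocarbamoyl in place of cyano on an aromatic carbon. Among the compounds with values here, the only measured step that bears on this change is the one from compound 1 to compound 2, and its size is not readable. With both neighbours at limits, no step beyond the scatter is expected in this assay in either direction. Compound 3 is therefore expected to give 300000 nM, between 100000 nM and 1000000 nM, quite possibly reported only as a limit. The step of an at least 1.0-fold lower number from compound 1 to compound 3 (0.02 log units; that floor lies within the scatter) is an estimate only.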

Compound 3, half-maximal inhibitory concentration: > 100000 nM
Compound 3 ended at the assay's limit; the forecaster's own chance of this, stated with the estimate: 85%; the middle value lies beyond the limit too.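

In this assay compound 3 gives > 100000 nM, a limit of the assay and not a number. Within the data shown here, neither the step from compound 1 to compound 3 nor the one from compound 2 to compound 3 can be read, as all three values are limits. The compounds shown leave open whether the cyano, thiocarbamoyl and aminocarbamoyl groups differ at all in this assay.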